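Nitro for Methoxy on the Aryl Ring of Compound 2

This account rests on a few compounds, and the source may have more. Where it says the series, first, only, none or still open, it means among the compounds named here.

Compound 2 `COc1ccc(N2CCN(Cc3csc(N)c3C(=O)c3ccc(Cl)cc3)CC2)cc1` gives 0% in an assay on CHO cells for displacement of a labelled ligand from adenosine receptor A1 (Homo sapiens), read by scintillation counting, with a stated time of 120 min, tested at 10 uM; on this read-out higher numbers stand for more inhibition at the one concentration tested (going by the name of the read-out) and lower numbers for less inhibition. Within the data shown here, the only other measured member of the series, compound 1 `Nc1scc(CN2CCN(c3cccc(Cl)c3Cl)CC2)c1C(=O)c1ccc(Cl)cc1`, gives 2% in this assay, so compound 2 stands within the scatter of the one number it can be compared with.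

Compound 3 `Nc1scc(CN2CCN(c3ccc([N+](=O)[O-])cc3)CC2)c1C(=O)c1ccc(Cl)cc1` is not yet measured. It differs from compound 2 by nitro in place of methoxy on an aromatic carbon.

Among the measured compounds shown here, one measured step bears on this change: the exchange of the whole aryl group on the amine nitrogen, which gave a number 2 percentage points lower from compound 1 to compound 2 (within the scatter). That a larger exchange on the same ring left the read-out essentially unchanged gives no reason to expect the smaller nitro-for-methoxy swap to move it beyond the scatter. Compound 3 is therefore expected to show a number 2 percentage points higher from compound 2 to compound 3 (within the scatter), with an estimated value of 2% in a range from -8% to 12%.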

Compound 3, a percentage reported as inhibition, at one concentration (the size of the read-out at that concentration, not a potency): 1%
The estimate for compound 3 lay 1 percentage points above the measured number; the measured number falls inside the stated range.
By their numbers in this assay, from the lowest: compounds 2, 3 and 1 (each within the scatter of the next).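

The nitro-for-methoxy exchange on an aromatic carbon, para to a large group, is now measured directly in this assay and gives a number 1 percentage points higher from compound 2 to compound 3 (within the scatter). Replacing the 2,3-dichlorophenyl group with 4-nitrophenyl on the same amine nitrogen gives a number 1 percentage points lower from compound 1 to compound 3 (within the scatter), so all three aryl groups now shown at this nitrogen lie within the scatter of one another. No measurement at hand accounts for this result.

The compounds leave open whether an amine or a carboxylic acid at the same aromatic carbon, or a longer chain in place of the aryl ring on the nitrogen, would give a number beyond the scatter. They also leave open whether an acetyl group on the free amine of the shared core would do so.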